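From 4-methoxyphenyl to 3-methoxyphenyl on the shared core

The source may report more compounds than this note shows. Statements on the series, on what has been measured and on what is new or still open speak of the compounds shown alone.

In a functional assay on MCF7 cells (Homo sapiens) for cytotoxicity, read by MTT assay, with a stated time of 48 h (on this read-out higher numbers stand for weaker inhibition and lower numbers for stronger inhibition), compound 1 (`O=C(CSc1nnc(-c2ccncc2)o1)N/N=C/c1ccc([N+](=O)[O-])cc1`) gives 31800 nM and compound 2 (`COc1ccc(/C=N/NC(=O)CSc2nnc(-c3ccncc3)o2)cc1`) gives 17600 nM as its half-maximal inhibitory concentration. For the measured compounds named here, these two values lie within the scatter of each other, so compound 2 is not separated from compound 1 on the numbers so far. Compound 3 (`COc1cccc(/C=N/NC(=O)CSc2nnc(-c3ccncc3)o2)c1`) has the same atoms as compound 2, joined differently: 3-methoxyphenyl in place of 4-methoxyphenyl on a carbon with a double bond to nitrogen with 3-methoxyphenyl in place of 4-methoxyphenyl on a carbon with a double bond to nitrogen. Going by the values given here, no measured step tests this change directly. The nearest guide is a 1.8-fold lower number from compound 1 to compound 2 (0.26 log units; within the scatter) for methoxy in place of nitro on an aromatic carbon, and that step stays within the scatter. No step beyond the scatter is therefore expected in this assay, and the estimated step is a 1.1-fold higher number from compound 2 to compound 3 (0.06 log units; within the scatter) as a working figure. For compound 3 the expected value is 20000 nM with an estimated range from 9000 nM to 45000 nM in this measurement.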

Compound 3, half-maximal inhibitory concentration: 13800 nM
The estimate for compound 3 lay 1.4-fold (0.16 log units) above the measured number, and the stated range covers the measured number.
By their numbers in this assay, from the lowest: compounds 3, 2 and 1 (each within the scatter of the next, the first and the last beyond it).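

In this assay, 3-methoxyphenyl in place of 4-methoxyphenyl on a carbon with a double bond to nitrogen gives a 1.3-fold lower number from compound 2 to compound 3 (0.11 log units; within the scatter), so the two methoxyphenyl groups are not separated at this place. 3-Methoxyphenyl in place of 4-nitrophenyl gives a 2.3-fold lower number from compound 1 to compound 3 (0.36 log units; beyond the scatter), a modest step but the first in this small set to pass beyond the scatter. No supporting evidence bears on this result.

The compounds shown leave open whether an amine or a carboxylic acid on the aromatic ring would give a number separated from those of the two methoxyphenyl compounds. They also leave open whether an ethoxy group or a longer chain in place of methoxy would do so.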